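This account rests on a few compounds, and the source may have more. Where it says the series, first, only, none or still open, it means among the compounds named here.

Among the measured compounds shown here, compound 3 `CC(C)(C)c1ccc(S(=O)(=O)Nc2ccc(Cl)cc2-c2nccc(CO)c2O)cc1` gives 8.7 nM in a functional assay on isolated protein for antagonist activity at C-C chemokine receptor type 9 (Homo sapiens), read by calcium flux, with a stated time of 10 min (on this read-out higher numbers stand for weaker inhibition and lower numbers for stronger inhibition), the lowest of the three numbers measured so far: compound 2 `CC(C)(C)c1ccc(S(=O)(=O)Nc2ccc(Cl)cc2-c2ncccc2CO)cc1` gives 89 nM and compound 1 `COc1cccnc1-c1cc(Cl)ccc1NS(=O)(=O)c1ccc(C(C)(C)C)cc1` gives 958 nM in this assay. Both measured steps onto compound 3 were large, a 110-fold lower number from compound 1 to compound 3 (2.04 log units; beyond the scatter) and a 10-fold lower number from compound 2 to compound 3 (1.01 log units; beyond the scatter), as was an 11-fold lower number from compound 1 to compound 2 (1.03 log units; beyond the scatter). Compound 4 `CC(C)(C)c1ccc(S(=O)(=O)Nc2ccc(Cl)cc2-c2ncnc(CO)c2O)cc1` differs from compound 3 by a group of 9 heavy atoms (5 carbon, 2 nitrogen, 2 oxygen; one six-membered aromatic ring with 2 hetero atoms) in place of a group of 9 heavy atoms (6 carbon, 1 nitrogen, 2 oxygen; one six-membered aromatic ring with 1 hetero atom), on an aromatic carbon, on an aromatic carbon of a six-membered aromatic ring of carbon only, ortho to a large group and meta to a chloro group. For the measured compounds named here, no measured step changes the number of hetero atoms in that ring; the earlier steps changed substituents on it, so they do not bear directly on this change. Absent such a guide, no step beyond the scatter is expected, meaning a 1.4-fold higher number from compound 3 to compound 4 (0.14 log units; within the scatter). For compound 4 an estimated 12 nM is expected in this assay, with a range from 4 nM to 40 nM.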

Compound 4, half-maximal inhibitory concentration: 11 nM
Compound 4: the middle estimate sits 1.1-fold (0.04 log units) above what was measured; the measured number falls inside the stated range.
By their numbers in this assay, from the lowest: compounds 3 and 4 (each within the scatter of the next); then compound 2; then compound 1.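

Among the compounds shown here, a ring with 2 hetero atoms is accepted at this place in this assay, since a 1.3-fold higher number from compound 3 to compound 4 (0.10 log units; within the scatter) is the first measured change in the hetero atom count of that ring and it stays within the scatter. For the compounds shown here, the advantage over the earlier compounds remains, with an 8.1-fold lower number from compound 2 to compound 4 (0.91 log units; beyond the scatter) and an 87-fold lower number from compound 1 to compound 4 (1.94 log units; beyond the scatter). No evidence is available to explain these results. Still open, as far as these compounds go, is whether an amine or a carboxylic acid in place of the hydroxymethyl would be accepted on the ring with 2 hetero atoms.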